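The source may report more compounds than this note shows. Statements on the series, on what has been measured and on what is new or still open speak of the compounds shown alone.

Going by the values given here, in a functional assay on HCT-116 cells (Homo sapiens) for cytotoxicity, read by MTT assay, with a stated time of 24 h (on this read-out higher numbers stand for weaker inhibition and lower numbers for stronger inhibition), compound 2 `COc1ccc(-n2cc(COc3c(/C=C\C(=O)O)ccc(OC)c3CC=C(C)C)nn2)cc1` gives 8700 nM, and it is the only compound with a number. Compound 1 `COc1ccc(/C=C\C(=O)O)c(OCc2cn(-c3ccc(NC(C)=O)cc3)nn2)c1CC=C(C)C`, which shares the same core, gives "not determined" (no result reported) in this assay, so it offers nothing to compare. Compound 3 `COc1ccc(/C=C\C(=O)O)c(OCc2cn(-c3nc4ccccc4s3)nn2)c1CC=C(C)C`, also built on the shared core, is not yet measured. It differs from compound 2 in a single place: 1,3-benzothiazol-2-yl in place of 4-methoxyphenyl on an aromatic nitrogen. Among the compounds with values here, no step between two measured compounds is available here, so the size of this change cannot be read from any earlier pair. Since only the number of compound 2 is known, the most reasonable expectation is that the step from compound 2 to compound 3 stays within the usual scatter, a 1.2-fold lower number from compound 2 to compound 3 (0.09 log units; within the scatter), with no clear direction. For compound 3 in this assay the estimate is 7000 nM, expected to lie between 1500 nM and 30000 nM.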

Compound 3, half-maximal inhibitory concentration: 16400 nM
Estimate against measurement, compound 3: 2.3-fold (0.37 log units) below, within the range that was stated.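

In this assay, going by these compounds alone, the first readable step at this position, on an aromatic nitrogen, is a 1.9-fold higher number from compound 2 to compound 3 (0.28 log units; within the scatter). This shows that 1,3-benzothiazol-2-yl, with its five-membered aromatic ring with 2 hetero atoms alongside a six-membered carbon ring, can take the place of 4-methoxyphenyl without a difference that stands clear of the usual scatter on this read-out. Nothing measured here explains why these two groups read alike.

Steps involving compound 1 cannot be read, as it carries no number. As far as these compounds go, it remains open whether a group of a different kind on this aromatic nitrogen, such as a plain butyl chain or a phenyl ring bearing an amine or a carboxylic acid, would move the number beyond the scatter.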